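The source may report more compounds than this note shows. Statements on the series, on what has been measured and on what is new or still open speak of the compounds shown alone.

Compound 3, `Cn1cc(-c2cc(C(O)(C(F)(F)F)C(F)(F)F)cnc2N2CCN(S(=O)(=O)c3ccc(N)nc3)CC2)cn1`, is examined in an ADME assay (liver) for metabolic stability, with Liver microsome (Homo sapiens) as the target, using microsomes and NADPH, with a stated time of 30 min, tested at 1 uM; a lower number here means slower removal, a higher number faster removal of the compound. In this assay compound 3 gives 19 mL.min-1.g-1. Its closest neighbour among the measured compounds is compound 1, `Nc1ccc(S(=O)(=O)N2CCN(c3ncc(C(O)(C(F)(F)F)C(F)(F)F)cc3C3CC3)CC2)cn1`, which in this assay gives 38 mL.min-1.g-1; the step of a 2.0-fold lower number from compound 1 to compound 3 (0.30 log units; within the scatter) places the two within the scatter of each other. Compound 2, `CC(C)(O)C#Cc1cc(C(O)(C(F)(F)F)C(F)(F)F)cnc1N1CCN(S(=O)(=O)c2ccc(N)nc2)CC1`, is the third measured compound. In this assay compound 2 gives < 14 mL.min-1.g-1, which is a limit of the assay rather than a number (the limit of < 14 mL.min-1.g-1 in this assay, at which 1 of the 3 values shown sits). The step of an at least 1.3-fold higher number from compound 2 to compound 3 (0.13 log units; that floor lies within the scatter) is therefore known only as a floor, and the step of an at least 2.7-fold lower number from compound 1 to compound 2 (0.43 log units; beyond the scatter) is beyond the scatter only at its lower edge.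

Compound 4, `Nc1ccc(S(=O)(=O)N2CCN(c3ncc(C(O)(C(F)(F)F)C(F)(F)F)cc3-c3ccncc3)CC2)cn1`, differs from compound 3 in one place: pyridin-4-yl in place of 1-methyl-1H-pyrazol-4-yl on an aromatic carbon. Among the compounds with values here, no measured step exchanges one aromatic group for another at this position, so the most relevant comparison is the pair of changes at the same aromatic carbon, both of which moved the number by amounts that stay within or at the edge of the scatter. On that basis a step of no more than the scatter is expected for compound 4, with the estimated step of a 1.2-fold higher number from compound 3 to compound 4 (0.06 log units; within the scatter). In this assay compound 4 is expected to give about 22 mL.min-1.g-1, within a range from 11 mL.min-1.g-1 to 45 mL.min-1.g-1.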

Compound 4, intrinsic clearance in microsomes: 15 mL.min-1.g-1
For compound 4 the middle estimate is 1.5-fold (0.17 log units) above the measured one; low and high end bracket the measured number.
By their numbers in this assay, from the lowest: compounds 4, 3 and 1 (each within the scatter of the next, the first and the last beyond it). At a limit, below all of these: compound 2.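

An exchange of one aromatic ring for another at this carbon, two atoms from the ring nitrogen, gives a 1.3-fold lower number from compound 3 to compound 4 (0.10 log units; within the scatter), so this assay does not separate pyridin-4-yl from 1-methyl-1H-pyrazol-4-yl here. Measured against cyclopropyl, pyridin-4-yl gives a 2.5-fold lower number from compound 1 to compound 4 (0.40 log units; beyond the scatter), which is beyond the scatter and rests on two real numbers, whereas the corresponding step with the pyrazole, a 2.0-fold lower number from compound 1 to compound 3 (0.30 log units; within the scatter), stays within it. Compound 2 remains at a limit of the assay rather than a number, so an at least 1.0-fold higher number from compound 2 to compound 4 (0.02 log units; that floor lies within the scatter) is known only as a floor and does not place 3-hydroxy-3-methylbut-1-yn-1-yl relative to pyridin-4-yl: the limit of < 14 mL.min-1.g-1 in this assay, at which 1 of the 4 values shown sits.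

The compounds shown leave open whether the ring nitrogen's placement matters, as a pyridin-3-yl or pyridin-2-yl group at this carbon would show, and whether a non-aromatic ring such as morpholine would read like cyclopropyl or like the aromatic groups. They also leave open how far the 3-hydroxy-3-methylbut-1-yn-1-yl group lies from the others, and whether a simple methoxy group or a nitrile at this carbon would fall in the same range.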